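Solubility across aryl variants of a cyclic phosphate prodrug

The source may hold more compounds than are shown below. What is called first, only, known or untested is meant among the compounds shown, and "the series" means these compounds.

Measured compounds in a physicochemical assay for solubility, in phosphate buffer, at pH 7.4; on this read-out lower numbers stand for lower solubility and higher numbers for higher solubility:
compound 1 `Nc1ccn([C@@H]2O[C@H](COP3(=O)OCC[C@H](c4cccc(Cl)c4)O3)[C@@H](O)[C@@H]2O)c(=O)n1`: 1700 ug/mL
compound 2 `Nc1ccn([C@@H]2O[C@H](COP3(=O)OCC[C@H](c4cc(Cl)cc(Cl)c4)O3)[C@@H](O)[C@@H]2O)c(=O)n1`: 500 ug/mL
compound 3 `Nc1ccn([C@@H]2O[C@H](COP3(=O)OCC[C@H](c4ccncc4)O3)[C@@H](O)[C@@H]2O)c(=O)n1`: 16700 ug/mL; > 200000 ug/mL (2 entries)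

Compound 2 gives the lowest of the two plain numbers in this assay; the nearest is compound 1, and a 3.4-fold lower number from compound 1 to compound 2 (0.53 log units; beyond the scatter). Compound 3 has several entries: the one plain number is the one given above, and the remaining entries of compound 3 are limits of the assay, not numbers, as in the several entries of compound 3 in this assay, 16700 ug/mL; > 200000 ug/mL (2 entries).

The next compound, compound 4 `Nc1ccn([C@@H]2O[C@H](COP3(=O)OCC[C@H](c4cccnc4)O3)[C@@H](O)[C@@H]2O)c(=O)n1`, differs from compound 2 by pyridin-3-yl in place of 3,5-dichlorophenyl on a saturated ring carbon. Among the compounds with values here, no measured step covers this exchange directly. Within the data shown here, the only measured step, a 3.4-fold lower number from compound 1 to compound 2 (0.53 log units; beyond the scatter), is a modest drop on adding a second chloro; compound 4 removes both chloro groups and brings in the pyridinyl ring. Among the measured compounds shown here, compound 3, which carries pyridin-4-yl in the same place, shows numbers far above compound 2, as its value above indicates, although no step between compound 2 and compound 3 has been worked out here.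

For compound 4 a large rise in this assay is therefore expected, estimated at 15000 ug/mL (range 3000 ug/mL to 100000 ug/mL), which means an expected step of a 30-fold higher number from compound 2 to compound 4 (1.48 log units; beyond the scatter). Given the limit entries of compound 3, a limit rather than a number is also possible for compound 4.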

Compound 4, solubility: 176000 ug/mL
Compound 4: the middle estimate sits 12-fold (1.07 log units) below what was measured; measured number above the stated range.
By their numbers in this assay, from the lowest: compound 2; then compound 1; then compound 4.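

Exchanging the aryl group on the saturated ring carbon next to the ring oxygen moves the read-out in this assay much further than the chloro change did, with a 350-fold higher number from compound 2 to compound 4 (2.55 log units; beyond the scatter) and a 100-fold higher number from compound 1 to compound 4 (2.02 log units; beyond the scatter), set against a 3.4-fold lower number from compound 1 to compound 2 (0.53 log units; beyond the scatter). Both steps into compound 4 are large, whether one or two chloro groups leave, so in these compounds the exchange of the chlorinated phenyl for pyridin-3-yl outweighs the chloro count. Compound 4 also gives the series a pyridinyl member with a single plain number in this assay, which shows that the high range is reached with the ring nitrogen in a second arrangement, and the series now has a clear split between the chlorophenyl compounds and compound 4.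

Within the data shown here, compound 3 carries limits of the assay alongside a plain number, so no step between it and compound 4, which differ by pyridin-4-yl and pyridin-3-yl, can be read: the several entries of compound 3 in this assay, 16700 ug/mL; > 200000 ug/mL (2 entries). Where an aminophenyl or a carboxylic acid on the aromatic ring at this carbon would fall on this scale stays open, as does whether a chloro group on the pyridin-3-yl ring would give back any of the step.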